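This account rests on a few compounds, and the source may have more. Where it says the series, first, only, none or still open, it means among the compounds named here.

a physicochemical assay for lipophilicity (on this read-out lower numbers stand for lower lipophilicity and higher numbers for higher lipophilicity), has so far given these values:

Compound 1 `CCn1cnc2c(-c3ccc(F)c(-c4ccc(S(=O)(=O)CC)cc4)c3)cnnc21` gives 2.9
Compound 2 `CCn1cnc2c(-c3ccc(F)c(-c4cccc(C(=O)NC)c4)c3)cnnc21` gives 2.8
Compound 3 `CCc1cnn2c(-c3ccc(F)c(-c4ccc(S(=O)(=O)CC)cc4)c3)cnnc12` gives 3.5

Compound 1 and compound 2 lie within the scatter of each other, while compound 3 lies beyond the scatter on the higher side of compound 1. Compound 4 `CCn1cnc2c(-c3ccc(F)c(-c4ccc(S(=O)(=O)CC)cc4Cl)c3)cnnc21` is compound 1 with a single change chloro in place of hydrogen on an aromatic carbon, ortho to a large group and meta to an ethylsulfonyl group. For the measured compounds named here, no pair of measured compounds shows this change, so the expectation rests on the change alone. In this assay a modest rise is expected, with the estimated step of a number 0.40 log units higher from compound 1 to compound 4 (beyond the scatter) falling just beyond the scatter. For compound 4 the estimated value is 3.3, with an expected range from 3 to 3.7.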

Compound 4, distribution coefficient: 3.2
The estimate for compound 4 lay 0.10 log units above the measured number; the range from low to high includes it.
By their numbers in this assay, from the lowest: compounds 2, 1, 4 and 3 (each within the scatter of the next, the first and the last beyond it).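

In this assay, for the compounds shown here, chloro in place of hydrogen on an aromatic carbon gives the first step between compounds that differ in one place: a number 0.30 log units higher from compound 1 to compound 4 (within the scatter) and so, at this position ortho to a large group and meta to an ethylsulfonyl group, the change does not clearly separate compound 4 from compound 1. Nothing at hand gives a reason for the size of this step.

On these data alone, whether methoxy or an amine at the same position would give a step beyond the scatter stays open. So does whether chloro would give a similar step on the core of compound 3.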